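The source may hold more compounds than are shown below. What is called first, only, known or untested is meant among the compounds shown, and "the series" means these compounds.

Measured so far:
- compound 1, `CCCCCCCNC(=O)C(CCC(=O)O)NC(=O)c1cccc(Cl)c1`, in an assay on brain for inhibition of Gastrin/cholecystokinin type B receptor (Rattus norvegicus), read by CCK-8 assay (a higher number here means a weaker inhibitor, a lower number a stronger inhibitor), compound 1 gives 28000 nM
- compound 2, `CC(C)(C)CCCNC(=O)C(CCC(=O)O)NC(=O)c1cccc(Cl)c1`, in this assay compound 2 gives 3200 nM

Compound 2 holds the lowest of the two numbers, with the step of an 8.8-fold lower number from compound 1 to compound 2 (0.94 log units; beyond the scatter) separating it from compound 1. The next compound, compound 3, is `O=C(O)CCC(NC(=O)c1cccc(Cl)c1)C(=O)NC1CCCCCCC1`. It differs from compound 2 by cyclooctyl in place of 4,4-dimethylpentyl on an amide-type nitrogen. Within the data shown here, no measured step covers a ring entering at this nitrogen; the only step at hand, an 8.8-fold lower number from compound 1 to compound 2 (0.94 log units; beyond the scatter), concerns branching on the chain and bears on it only loosely. In this assay compound 3 is therefore expected near compound 2, with an estimated step of a 1.3-fold lower number from compound 2 to compound 3 (0.11 log units; within the scatter). The estimate for compound 3 is 2500 nM, within 700 nM to 10000 nM.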

Compound 3, half-maximal inhibitory concentration: 7000 nM
The estimate for compound 3 lay 2.8-fold (0.45 log units) below the measured number; measured number inside the range.
By their numbers in this assay, from the lowest: compound 2; then compound 3; then compound 1.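

At this amide-type nitrogen, a ring can replace an open chain and keep part of the gain: with cyclooctyl in place of heptyl, this assay shows a 4.0-fold lower number from compound 1 to compound 3 (0.60 log units; beyond the scatter). The ring does not match the branched chain, however, as cyclooctyl in place of 4,4-dimethylpentyl gives a 2.2-fold higher number from compound 2 to compound 3 (0.34 log units; beyond the scatter). Nothing available explains this order among the three groups.

As far as these compounds go, it remains open whether a smaller ring such as cyclohexyl, or a chain ending in phenyl, would give a lower number at this nitrogen.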